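Methylsulfanyl in place of hydrogen on the pendant phenyl ring

The source may hold more compounds than are shown below. What is called first, only, known or untested is meant among the compounds shown, and "the series" means these compounds.

Compound 1, `O=C(CCc1cccc2c1B(O)OC2)Nc1cccc(-c2ccccc2)c1`: 12000 nM
Compound 2, `O=C(CCc1cccc2c1B(O)OC2)Nc1cccc(-c2ccc(OC(F)(F)F)cc2)c1`: 25000 nM

Among the measured compounds shown here, in an ADME assay on WI-38 cells (Homo sapiens) for cytotoxicity, read by MTT assay, with a stated time of 72 h (a higher number here means a weaker inhibitor, a lower number a stronger inhibitor), compound 1 gives 12000 nM, the lowest of the two numbers measured so far. Compound 2 gives 25000 nM. For the measured compounds named here, the single measured step, a 2.1-fold higher number from compound 1 to compound 2 (0.32 log units; beyond the scatter), shows a modest rise when a group enters on an aromatic carbon of the phenyl ring in place of hydrogen.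

Compound 3, `CSc1cccc(-c2cccc(NC(=O)CCc3cccc4c3B(O)OC4)c2)c1`, differs from compound 1 by methylsulfanyl in place of hydrogen on an aromatic carbon. Going by the values given here, only the step from compound 1 to compound 2 bears on this change, and it is modest; the entering group here is a different one, so that step is a loose guide. A small upward step in this assay, or none beyond the scatter, is therefore expected. The estimated step of a 1.4-fold higher number from compound 1 to compound 3 (0.15 log units; within the scatter) reflects that view. Compound 3 is expected to give 17000 nM, with a range from 8000 nM to 40000 nM.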

Compound 3, half-maximal inhibitory concentration: 2000 nM
Beside the measured number, compound 3's estimate is 8.5-fold (0.93 log units) above it; the measured number lies below the stated range.
By their numbers in this assay, from the lowest: compound 3; then compound 1; then compound 2.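

In this assay, methylsulfanyl in place of hydrogen, meta to a large group, gives a 6.0-fold lower number from compound 1 to compound 3 (0.78 log units; beyond the scatter) and so runs opposite to a 2.1-fold higher number from compound 1 to compound 2 (0.32 log units; beyond the scatter) with trifluoromethoxy, which shows that a group entering on this ring need not raise the number. Compound 2 and compound 3 differ in more than one place, so these two steps cannot separate the effect of the entering group from that of where it sits. Nothing measured here accounts for the size or direction of the new step.

The compounds shown leave open whether the lower number depends on the sulfur, which a methoxy group at the same place would test. They also leave open how an amine or a carboxylic acid there would compare, and whether methylsulfanyl elsewhere on the ring would give a similar step.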